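Notes on the step from compound 3 to compound 4

The compounds below may be only part of what the source reports. "The series", "measured", "known", "first", "only" and "open" are said of these compounds alone.

- compound 1 `Nc1nc(N)c2cc(CSC(=S)N3CCN(c4ccc(Cl)cc4)CC3)ccc2n1`: 4880 nM
- compound 2 `Nc1nc(N)c2cc(CSC(=S)N3CCN(c4ccc(Cl)c(Cl)c4)CC3)ccc2n1`: 2370 nM
- compound 3 `Nc1nc(N)c2cc(CSC(=S)N3CCN(c4ccccc4[N+](=O)[O-])CC3)ccc2n1`: 4350 nM

All three values come from a functional assay on MCF7 cells (Homo sapiens) for antiproliferative activity, read by MTT assay, with a stated time of 72 h; a higher number here means a weaker inhibitor, a lower number a stronger inhibitor. Compound 3 stands within the scatter of both other compounds, and the two gaps are set out below.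

The next structure is compound 4 `Nc1nc(N)c2cc(CSC(=S)N3CCN(c4ccc(C(F)(F)F)cc4)CC3)ccc2n1`, which has 4-(trifluoromethyl)phenyl in place of 2-nitrophenyl on an amine nitrogen in a ring.

Two measured steps change the same group on that nitrogen. With 2-nitrophenyl in place of 4-chlorophenyl the result is a 1.1-fold lower number from compound 1 to compound 3 (0.05 log units; within the scatter). With 2-nitrophenyl in place of 3,4-dichlorophenyl the result is a 1.8-fold higher number from compound 2 to compound 3 (0.26 log units; within the scatter). Among the compounds with values here, the one step that goes against this quiet picture is a 2.1-fold lower number from compound 1 to compound 2 (0.31 log units; beyond the scatter), a modest step with chloro in place of hydrogen. Within the data shown here, no measured compound carries trifluoromethyl, so the expectation rests on these few exchanges alone.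

On that basis, no change beyond the scatter is expected, and the estimated step is a 1.2-fold lower number from compound 3 to compound 4 (0.09 log units; within the scatter).

For compound 4 the estimated value is 3500 nM, with an expected range from 1500 nM to 7500 nM.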

Compound 4, half-maximal inhibitory concentration: 7400 nM
The estimate for compound 4 lay 2.1-fold (0.33 log units) below the measured number; the measured number falls inside the stated range.
By their numbers in this assay, from the lowest: compounds 2, 3, 1 and 4 (each within the scatter of the next, the first and the last beyond it).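

In this assay, 4-(trifluoromethyl)phenyl in place of 2-nitrophenyl on the amine nitrogen leaves the number within the scatter (a 1.7-fold higher number from compound 3 to compound 4 (0.23 log units; within the scatter)), and trifluoromethyl in place of chloro on an aromatic carbon does the same (a 1.5-fold higher number from compound 1 to compound 4 (0.18 log units; within the scatter)), so neither exchange resolves compound 4 from its closest neighbours. Within the data shown here, the new information lies in the exchange of 3,4-dichlorophenyl for 4-(trifluoromethyl)phenyl (a 3.1-fold higher number from compound 2 to compound 4 (0.49 log units; beyond the scatter)), the first step beyond the scatter among the exchanges of the whole group on this nitrogen, though still a modest one, which widens the spread of the series without separating compound 1 or compound 3 from compound 4. Nothing available accounts for the size or direction of any of these steps.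

Going by these compounds, whether a plain phenyl, a benzyl or an acetyl group on this nitrogen would fall nearer compound 2 or compound 4 remains open, as does the effect of a methoxy or nitrile group on the aromatic ring. On these data alone, all four compounds also share the same core and the same link to the piperazine-type ring, so how much of the number depends on those parts is untested here.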